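Aryl-to-Aryloxymethyl Change at an Aromatic Carbon

The compounds below may be only part of what the source reports. "The series", "measured", "known", "first", "only" and "open" are said of these compounds alone.

Measured so far:
Compound 1 `O=C(O)CCCSCCN1C(=O)CC[C@@H]1/C=C/[C@@H](O)Cc1cccc(-c2nc3ccccc3s2)c1` gives 720 nM in an assay on CHO cells for displacement of a labelled ligand from prostaglandin E2 receptor EP2 subtype (Mus musculus), read by scintillation counting, with a stated time of 60 min; a higher number here means a weaker inhibitor, a lower number a stronger inhibitor.
Compound 2 `O=C(O)CCCSCCN1C(=O)CC[C@@H]1/C=C/[C@@H](O)Cc1cccc(-c2cc3ccccc3o2)c1` gives 2000 nM in this assay.

Compound 2 stands with the highest of the two numbers shown; its nearest neighbour is compound 1, and the single measured step shows a 2.8-fold higher number from compound 1 to compound 2 (0.44 log units; beyond the scatter). Compound 3 `O=C(O)CCCSCCN1C(=O)CC[C@@H]1/C=C/[C@@H](O)Cc1cccc(OCc2ccncc2)c1` is a further change at the same place: (pyridin-4-yl)methoxy in place of 1-benzofuran-2-yl on an aromatic carbon. Within the data shown here, only one measured step exists, and it swaps one two-ring group for another, which is not the change made here. It shows that this position can move the number beyond the scatter, but gives no direction for swapping a two-ring group for a one-ring group joined through oxygen. The expected step from compound 2 to compound 3 is therefore a 1.3-fold higher number from compound 2 to compound 3 (0.10 log units; within the scatter), with wide uncertainty. Compound 3 is estimated at 2500 nM, with a range from 600 nM to 10000 nM.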

Compound 3, inhibition constant: > 10000 nM
Compound 3 was reported as a limit (the forecaster's own chance of this, stated with the estimate: 10%); middle value at least 4.0-fold (0.60 log units) away from the limit.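

Compound 3 is reported in this assay only as a limit, not as a number: the limit of > 10000 nM in this assay, at which 1 of the 3 values shown sits. Even so, (pyridin-4-yl)methoxy in place of 1-benzofuran-2-yl gives an at least 5.0-fold higher number from compound 2 to compound 3 (0.69 log units; beyond the scatter), and the same group in place of 1,3-benzothiazol-2-yl gives an at least 13-fold higher number from compound 1 to compound 3 (1.14 log units; beyond the scatter). Unlike the swap between the two two-ring groups, this change takes the number at this position out of the measured range, so compound 3 is the weakest of the three.

This single change removes a ring, adds a link through oxygen and brings in a ring nitrogen, and the compounds shown cannot separate these three differences. A benzyloxy group, or a pyridin-4-yl group joined directly to the aromatic carbon, would help to tell them apart.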